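A few compounds are considered here, and "the series" means these few. Any claim that something is new, unique, unknown or untested is made for them only; others in the source may bear on it.

Working notes on the pyranone series.

Compound 1 `CCCC#Cc1cc(C)oc(=O)c1` is the anchor of the set. Going by the values given here, in a functional assay on K562 cells (Homo sapiens) for inhibition (on this read-out lower numbers stand for stronger inhibition and higher numbers for weaker inhibition), compound 1 gives 17800 nM, which is the only number in the set so far, and it stands alone. Compound 2 `Cc1cc(-c2ccccc2)cc(=O)o1` gives > 50000 nM in this assay, and that reading is a limit, not a measured value. Among the compounds with values here, of the two values shown, then, one sits at the limit of > 50000 nM in this assay, at which 1 of the 2 values shown sits, so no step between measured compounds can be drawn and no direction is established.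

Compound 3 `CCCCCC#Cc1cc(C)oc(=O)c1` is the next member to be measured. It differs from compound 1 by ethyl in place of hydrogen on a saturated chain carbon, three bonds along the chain from a triple-bonded carbon. The change extends the alkyl chain without adding a ring, a donor or an acceptor. Within the data shown here, with no measured step on this chain to rest on, the expectation is a step of no more than the usual scatter, in no particular direction: compound 3 is expected at 15000 nM, within 6000 nM to 40000 nM, so that the estimated step from compound 1 to compound 3 is a 1.2-fold lower number from compound 1 to compound 3 (0.07 log units; within the scatter).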

Compound 3, half-maximal inhibitory concentration: 11100 nM
Compound 3: middle estimate off by 1.4-fold (0.13 log units), on the high side, within the range that was stated.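

In this assay, going by these compounds alone, the first step that can be read on this chain is a 1.6-fold lower number from compound 1 to compound 3 (0.21 log units; within the scatter) and it is the only measured step. On this saturated chain carbon, three bonds along the chain from a triple-bonded carbon, ethyl in place of hydrogen leaves the reading within what repeated measurements would give, so this extension of the chain is not shown to matter in this assay. The earlier compounds shown here offered no step at all; this pair supplies one, but it sets no direction that can be relied on.

On these data alone, whether a longer chain such as octyl, or a chain ending in an amine or a carboxylic acid, would move the number beyond the scatter stays open, as does any trend with chain length, which a single step cannot establish. Compound 2 remains a limit and adds no step to the series: the limit of > 50000 nM in this assay, at which 1 of the 3 values shown sits.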